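The compounds below may be only part of what the source reports. "The series", "measured", "known", "first", "only" and "open" are said of these compounds alone.

Of the compounds shown here, three that share an ester-linked core have been tested in a functional assay on EA.hy 926 cells (Homo sapiens) for cytotoxicity, read by MTT assay, with stated times of 24 h and 12 h, tested at 25 uM; on this read-out lower numbers stand for a weaker effect and higher numbers for a stronger effect at the one concentration tested. Compound 1 `CCOC(=O)/C=C/c1ccc(OC(=O)c2nc(C)c(C)nc2C)c(O)c1` gives 207%. Compound 2 `Cc1nc(C)c(C(=O)Oc2cccc(/C=C/C(=O)O)c2)nc1C` gives 64.3%. Compound 3 `Cc1nc(C)c(C(=O)Oc2ccc(/C=C/C(=O)O)cc2O)nc1C` gives 271%. Compound 2 thus stands lowest of the three numbers, with compound 1 nearest to it and compound 3 furthest from it, both gaps lying beyond the usual scatter of the method.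

Compound 3 and compound 1 differ in a single place: ethyl in place of hydrogen on an oxygen next to a carbonyl group. This change produced a number 64 percentage points lower from compound 3 to compound 1 (beyond the scatter).

Compound 4 `CCOC(=O)/C=C/c1cccc(OC(=O)c2nc(C)c(C)nc2C)c1` has not yet been measured in this assay. It differs from compound 2 in one place: ethyl in place of hydrogen on an oxygen next to a carbonyl group. The place of the change reads the same in both pairs, so this is the same change carried out on a different core. How the core of compound 2 differs from the core of compound 3 is not broken down here.

Among the compounds with values here, the earlier pair gives the only guide. Because the same change gave a number 64 percentage points lower from compound 3 to compound 1 (beyond the scatter), a fall is expected here too. Yet the starting point of compound 2, 64.3%, is already low, and the earlier pair started from a much higher number, so a smaller fall is expected. The expected step is a number 24.3 percentage points lower from compound 2 to compound 4 (beyond the scatter). Compound 4 is therefore estimated at 40%, most likely falling between 10% and 85%.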

Compound 4, a percentage reported as activity, at one concentration (the size of the read-out at that concentration, not a potency): 34.2%
Estimate against measurement, compound 4: 5.8 percentage points above; the range from low to high includes it.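

Replacing the hydrogen with ethyl, which turns carboxy into ethoxycarbonyl, gave in this assay a number 30.1 percentage points lower from compound 2 to compound 4 (beyond the scatter), so the fall seen on the first core also appears on the second. The direction carried over, but the size did not, and the two steps differ by more than repeated measurements would explain: the same change on two cores in this assay, a number 64 percentage points lower (beyond the scatter) from compound 3 to compound 1 and a number 30.1 percentage points lower (beyond the scatter) from compound 2 to compound 4, 33.9 percentage points apart, beyond the scatter of two such steps

Two pairs show a shared direction on these two cores, not a rule for the series, and they do not reveal which feature of a core sets the size of the step. Because the two cores also start from very different numbers, the pairs cannot separate an effect of the core itself from an effect of the starting level, and each result comes from a single concentration.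

The compounds shown leave open how a methyl group or a longer chain such as butyl would behave on this oxygen, and whether the numbers would fall by a similar amount with either of them. They also leave open what an amide in place of the ethyl ester would do on either core, and whether it would follow the same direction.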